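Lipophilicity notes: pyridyl for ethoxyphenyl on the biaryl

The compounds below may be only part of what the source reports. "The series", "measured", "known", "first", "only" and "open" are said of these compounds alone.

Measured compounds in a physicochemical assay for lipophilicity, read by HPLC, at pH 7.5; a higher number here means a more lipophilic compound, a lower number a more polar compound:
- compound 1 `CCOc1ccccc1-c1ccc(-c2nc3cnccc3c(N[C@H](CC)C(N)=O)c2C#N)cc1`: 3
- compound 2 `CCOc1ccccc1-c1ccc(-c2nc3cnccc3c(C[C@H](C)C(=O)O)c2C#N)cc1`: 2.2
- compound 3 `CCOc1ccccc1-c1ccc(-c2nc3cnccc3c(N)c2C#N)cc1`: 3

Compound 1 stands level with compound 3 at the digits printed, the two together giving the highest numbers of the three; the step of no change at the digits printed from compound 1 to compound 3 (within the scatter) lies within the scatter. Its furthest neighbour is compound 2, reached by a number 0.80 log units lower from compound 1 to compound 2 (beyond the scatter), and the return a number 0.80 log units higher from compound 2 to compound 3 (beyond the scatter) is of the same size. All three measured steps concern the group on the core bearing the nitrile, not the outer aryl ring.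

Compound 4 `CC[C@@H](Nc1c(C#N)c(-c2ccc(-c3cnccc3C)cc2)nc2cnccc12)C(N)=O` keeps that group of compound 1 unchanged and alters the outer ring instead:
4-methylpyridin-3-yl in place of 2-ethoxyphenyl on an aromatic carbon
Within the data shown here, no measured step bears on this change; the measured pairs vary only the other position. The expectation therefore rests on the change itself: a step of a number 0.80 log units lower from compound 1 to compound 4 (beyond the scatter) is expected, downward and beyond the scatter. For compound 4 the estimate in this assay is 2.2, with a range from 1.7 to 2.7.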

Compound 4, distribution coefficient: 2
Estimate against measurement, compound 4: 0.20 log units above, and the stated range covers the measured number.
By their numbers in this assay, from the lowest: compounds 4 and 2 (each within the scatter of the next); then compounds 1 and 3 (each within the scatter of the next).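

In this assay the outer ring on the biaryl proves to be a position that moves the number, with a step of a number 1.00 log units lower from compound 1 to compound 4 (beyond the scatter) while the group on the core stays that of compound 1. The swap of 2-ethoxyphenyl for 4-methylpyridin-3-yl brings a ring hetero atom and fewer heavy atoms, with the counts of hydrogen-bond donors and acceptors and the net charge unchanged. Nothing available explains the size of this step or divides it among the loss of the ethoxy group, the ring nitrogen and the methyl group.

The compounds shown leave open how much of the step would remain with a 2-ethoxypyridin-3-yl group, which keeps the ethoxy group on a pyridine ring, or with a plain pyridin-3-yl group, which lacks the methyl. Also open, from the compounds shown here alone, is whether 4-methylpyridin-3-yl gives a similar step when the core carries 2-carboxypropyl or amino.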